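Oxadiazole for Carbamate on the Piperidine Nitrogen

The compounds below may be only part of what the source reports. "The series", "measured", "known", "first", "only" and "open" are said of these compounds alone.

Compound 1 `CC(C)(C)OC(=O)N1CCC(CCCNc2ccc3c(c2)OCC3=O)CC1`: 108%
Compound 2 `CC(C)(C)OC(=O)N1CCC(CCCNc2ccc3c(c2)C(=O)CO3)CC1`: 116%

In a functional assay on CHO-K1 cells for agonist activity at Glucose-dependent insulinotropic receptor (Mus musculus), read by HTRF and cAMP accumulation, with a stated time of 30 min (on this read-out lower numbers stand for smaller maximal responses and higher numbers for larger maximal responses), compound 1 gives 108% and compound 2 gives 116%; the two values lie within the usual scatter of each other, so neither stands apart. Compound 3 `CC(C)c1nnc(N2CCC(CCCNc3ccc4c(c3)OCC4=O)CC2)o1` has not yet been measured. It differs from compound 1 in one place: 5-isopropyl-1,3,4-oxadiazol-2-yl in place of tert-butoxycarbonyl on an amine nitrogen in a ring. Among the measured compounds shown here, with no measured step of this kind available, compound 3 is expected to keep a full response, and its step of a number 3 percentage points lower from compound 1 to compound 3 (within the scatter) is estimated to stay within the scatter. Compound 3 is therefore estimated at 105%, within 80% to 125%.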

Compound 3, largest response reached (Emax), in percent of the reference or control that the assay uses: 88%
Estimate against measurement, compound 3: 17 percentage points above; the range from low to high includes it.
By their numbers in this assay, from the lowest: compound 3; then compounds 1 and 2 (each within the scatter of the next).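

In this assay, placing 5-isopropyl-1,3,4-oxadiazol-2-yl in place of tert-butoxycarbonyl on the amine nitrogen in the ring gives a step of a number 20 percentage points lower from compound 1 to compound 3 (beyond the scatter). The maximal response therefore depends on the group at this position, although the aromatic five-membered ring still leaves a sizeable response. No available evidence bears on the origin of this step. On these data alone, it remains open whether the same exchange would give a similar step on the core of compound 2, and whether an acetyl group or a pyrimidin-2-yl ring on this nitrogen would fall nearer compound 1 or compound 3.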